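This account rests on a few compounds, and the source may have more. Where it says the series, first, only, none or still open, it means among the compounds named here.

Working notes on the sulfonamide series, read in a functional assay on DLD-1 cells (Homo sapiens) for antiproliferative activity, read by CellTiter-Glo, with a stated time of 72 h; on this read-out lower numbers stand for stronger inhibition and higher numbers for weaker inhibition. Of the compounds shown here, three carry numbers so far. Compound 1 `CC1CCN(C2CCN(S(=O)(=O)c3ccc(C#N)cc3)CC2)CC1` gives 2800 nM, compound 2 `Cc1cc(C)c(S(=O)(=O)NCCN2CCC(C)CC2)c(C)c1` gives 1900 nM, and compound 3 `CC1CCN(C2CCN(S(=O)(=O)c3cnc(Cl)s3)CC2)CC1` gives 1800 nM. Among the measured compounds shown here, on these three numbers compound 3 stands at the low end, yet its distance to compound 2 is within the scatter, and the one measured step that reaches it, a 1.6-fold lower number from compound 1 to compound 3 (0.19 log units; within the scatter), is also within the scatter; so nothing here separates the three compounds beyond repeat-to-repeat variation.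

The next compound, compound 4 `CC1CCN(C2CCN(S(=O)(=O)c3ccc(Cl)nc3)CC2)CC1`, is not yet measured. It differs from compound 3 in one place: 6-chloropyridin-3-yl in place of 2-chloro-1,3-thiazol-5-yl on a sulfonyl sulfur. For the measured compounds named here, the only measured step that bears on this change is the aryl swap on the same sulfonyl sulfur, a 1.6-fold lower number from compound 1 to compound 3 (0.19 log units; within the scatter), which stayed within the scatter. Going by the values given here, no other pair speaks to a five-membered against six-membered aromatic ring at this position. The expectation is therefore a step of no size beyond the scatter, in either direction, meaning an estimated 1.1-fold higher number from compound 3 to compound 4 (0.05 log units; within the scatter). For compound 4 the expected number in this assay is 2000 nM, with a range from 900 nM to 4500 nM.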

Compound 4, half-maximal inhibitory concentration: 3700 nM
The estimate for compound 4 lay 1.9-fold (0.27 log units) below the measured number; low and high end bracket the measured number.
By their numbers in this assay, from the lowest: compounds 3, 2, 1 and 4 (each within the scatter of the next, the first and the last beyond it).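

In this assay, the group on the sulfonyl sulfur now gives its first step beyond the scatter, a 2.1-fold higher number from compound 3 to compound 4 (0.31 log units; beyond the scatter), so the exchange of 2-chloro-1,3-thiazol-5-yl for 6-chloropyridin-3-yl is not silent at this position, although the step is modest. Among the compounds shown here, the 6-chloropyridin-3-yl and 4-cyanophenyl groups are not told apart, with a 1.3-fold higher number from compound 1 to compound 4 (0.12 log units; within the scatter), so among the three groups on this sulfur only the pair carried by compound 3 and compound 4 separates, while compound 1 stays within the scatter of both. No measured data bear on the origin of this step.

From the compounds shown here alone, compound 2 differs from the others in more than one place and gives no reading of this change, so it remains open whether the step between the five-membered and six-membered aromatic rings holds on another core. Also open, going by these compounds, is how this position responds when an amine or a carboxylic acid takes the place of the chlorine in the 6-chloropyridin-3-yl group.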